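Bromo in place of iodo: expected read-out

A few compounds are considered here, and "the series" means these few. Any claim that something is new, unique, unknown or untested is made for them only; others in the source may bear on it.

In a functional assay on Vero cells (Chlorocebus sabaeus) for inhibition (on this read-out higher numbers stand for weaker inhibition and lower numbers for stronger inhibition), compound 1 `Nc1nc(=O)n([C@@H]2CS[C@@H](CO)O2)cc1I` gives > 100000 nM, which is a limit and not a number. Compound 2 `O=c1ccn([C@H]2CS[C@@H](CO)O2)c(=O)[nH]1` gives > 100000 nM, which is also a limit. Among the compounds with values here, the series so far therefore offers only (the limit of > 100000 nM in this assay, at which 2 of the 2 values shown sit). Compound 3 `Nc1nc(=O)n([C@@H]2CS[C@@H](CO)O2)cc1Br` has bromo in place of iodo on an aromatic carbon, ortho to an amino group: bromo in place of iodo on an aromatic carbon. Within the data shown here, no measured step is available to size this change, so no step beyond the scatter is expected in this assay, in either direction. The estimated step is a number no higher from compound 1 to compound 3 (the limit leaves the size open). For compound 3 the expected value is 100000 nM, with an estimated range of 50000 nM to 200000 nM.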

Compound 3, half-maximal inhibitory concentration: > 100000 nM
Compound 3 ended at the assay's limit; the forecaster's own chance of this, stated with the estimate: 85%; the middle value sits exactly at the limit.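

No step can be read from compound 1 to compound 3 in this assay, as both values are limits and not numbers: the limit of > 100000 nM in this assay, at which 3 of the 3 values shown sit.

Whether bromo in place of iodo alters inhibition at all stays open, as does what would bring any of these compounds to a readable value.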